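A methyl group added to a tert-butyl compound

The compounds below may be only part of what the source reports. "The series", "measured", "known", "first", "only" and "open" are said of these compounds alone.

Within the data shown here, in a functional assay on MDA-MB-231 cells (Homo sapiens) for inhibition, read by sulforhodamine B assay, with a stated time of 48 h (on this read-out lower numbers stand for stronger inhibition of growth and higher numbers for weaker inhibition of growth), compound 3 `CC(C)(C)c1nc2ncccn2c1CN1CCCCC1` has the highest number of the three measured so far, at 1490 nM, while compound 1 `Cc1ccn2c(CN3CCCCC3)c(-c3ccccc3)nc2n1` gives 30 nM and compound 2 `c1ccc(-c2nc3ncccn3c2CN2CCCCC2)cc1` gives 30 nM. Compound 4 `Cc1ccn2c(CN3CCCCC3)c(C(C)(C)C)nc2n1` carries one change from compound 3: methyl in place of hydrogen on an aromatic carbon. Among the measured compounds shown here, the closest precedent is the reverse swap, hydrogen in place of methyl, which gave no change at the digits printed from compound 1 to compound 2 (within the scatter). The large step, a 50-fold higher number from compound 2 to compound 3 (1.70 log units; beyond the scatter), came from a different change, tert-butyl in place of phenyl, so the methyl precedent comes only from phenyl compounds. No shift beyond the scatter is therefore expected in this assay. The estimated step is no change at the digits printed from compound 3 to compound 4 (within the scatter). Compound 4 is estimated at 1490 nM, with an expected range from 700 nM to 3000 nM.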

Compound 4, concentration for 50% growth inhibition: 350 nM
Estimate against measurement, compound 4: 4.3-fold (0.63 log units) above; measured number outside the range, below it.
By their numbers in this assay, from the lowest: compounds 1 and 2 (each within the scatter of the next); then compound 4; then compound 3.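

Adding methyl at this place is not neutral on every compound: with tert-butyl in the other position, this assay shows a 4.3-fold lower number from compound 3 to compound 4 (0.63 log units; beyond the scatter), whereas with phenyl there the same change left the number unmoved. The size of the methyl step therefore depends on the group it is paired with: the same change on two cores in this assay, no change at the digits printed (within the scatter) from compound 1 to compound 2 and a 4.3-fold higher number (0.63 log units; beyond the scatter) from compound 4 to compound 3, 4.3-fold (0.63 log units) apart, beyond the scatter of two such steps. The swap to tert-butyl also gives a smaller rise when methyl is present, with a 12-fold higher number from compound 1 to compound 4 (1.07 log units; beyond the scatter) as the step: the same change on two cores in this assay, a 50-fold higher number (1.70 log units; beyond the scatter) from compound 2 to compound 3 and a 12-fold higher number (1.07 log units; beyond the scatter) from compound 1 to compound 4, 4.3-fold (0.63 log units) apart, beyond the scatter of two such steps.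

Going by these compounds, whether ethyl or an amine at this place would behave like methyl remains open. So does whether cyclohexyl in place of tert-butyl would show the same dependence.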